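A few compounds are considered here, and "the series" means these few. Any claim that something is new, unique, unknown or untested is made for them only; others in the source may bear on it.

Compound 1 `COc1cc(C2CC(c3cccc4ccccc34)=NN2C(C)=O)ccc1OCc1cn(Cc2ccc([N+](=O)[O-])cc2)nn1` is the stronger of the two measured compounds: in a functional assay on A549 cells (Homo sapiens) for inhibition, read by sulforhodamine B assay, tested at 10 uM (a lower number here means less inhibition of growth, a higher number more inhibition of growth at the concentration tested), compound 1 gives 89%, while compound 2 `COc1cc(C2CC(c3ccc(OCc4cn(Cc5ccc([N+](=O)[O-])cc5)nn4)cc3)=NN2C(C)=O)ccc1Oc1cn(Cc2ccc([N+](=O)[O-])cc2)nn1` in this assay gives 29%, a gap beyond the usual scatter. Compound 3 `COc1cc(C2CC(c3cc(OC)c(OC)c(OC)c3)=NN2C(C)=O)ccc1OCc1cn(Cc2ccc([N+](=O)[O-])cc2)nn1` differs from compound 1 in one place (3,4,5-trimethoxyphenyl in place of naphthalen-1-yl on a carbon with a double bond to nitrogen). Within the data shown here, no measured pair shows what this change does. The expected shift from compound 1 to compound 3, a number 14 percentage points lower from compound 1 to compound 3 (beyond the scatter), is a moderate loss, since the whole naphthalen-1-yl group gives way to 3,4,5-trimethoxyphenyl. Compound 3 is estimated at 75%, within a range of 45% to 95%.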

Compound 3, percent growth inhibition at one concentration: 68%
Estimate against measurement, compound 3: 7 percentage points above; measured number inside the range.
By their numbers in this assay, from the lowest: compound 2; then compound 3; then compound 1.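

In this assay, placing 3,4,5-trimethoxyphenyl in place of naphthalen-1-yl on the carbon with a double bond to nitrogen gives a number 21 percentage points lower from compound 1 to compound 3 (beyond the scatter), so this position responds to the change, yet compound 3 keeps much of the growth inhibition. Two aromatic rings of carbon only can thus give way to one such ring bearing three methoxy groups without losing all inhibition. No measurement available gives a reason for this drop.

Still open, as far as these compounds go, is whether the change in ring count or the methoxy groups account for the step. A plain phenyl group at this position would help separate the two.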